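The source may report more compounds than this note shows. Statements on the series, on what has been measured and on what is new or still open speak of the compounds shown alone.

In a functional assay on 3T3-L1 cells (Mus musculus) for inhibition, with a stated time of 20 min, tested at 20 uM (on this read-out higher numbers stand for more inhibition at the one concentration tested (going by the name of the read-out) and lower numbers for less inhibition), compound 3 `COc1cc(Cn2cc(CN(Cc3c(-c4ccccc4)c4ccccc4n3S(=O)(=O)c3ccc(C)cc3)S(=O)(=O)c3ccc(C)cc3)nn2)cc(OC)c1OC` gives -10.9%, the second highest of three numbers. Its nearest neighbour is compound 1 `Cc1ccc(S(=O)(=O)N(Cc2cn(Cc3ccc(F)cc3)nn2)Cc2c(-c3ccccc3)c3ccccc3n2S(=O)(=O)c2ccc(C)cc2)cc1`, which in this assay gives -7.6%, within the scatter of compound 3; furthest away is compound 2 `O=C(N(Cc1ccc(F)cc1)Cc1cccc(F)c1F)C(F)(F)F`, which in this assay gives -39.8%, beyond the scatter. Compound 4 `Cc1ccc(S(=O)(=O)N(Cc2cn(Cc3ccccc3)nn2)Cc2c(-c3ccccc3)c3ccccc3n2S(=O)(=O)c2ccc(C)cc2)cc1` is not yet measured and differs from compound 3 in one place: phenyl in place of 3,4,5-trimethoxyphenyl on a saturated chain carbon bound to an aromatic nitrogen. Going by the values given here, the one measured step at the same place, a number 3.3 percentage points lower from compound 1 to compound 3 (within the scatter), was within the scatter, so a change of the group on that carbon is expected to move this assay little. Compound 4 is therefore expected to give -9%, between -25% and 7%, an expected step of a number 1.9 percentage points higher from compound 3 to compound 4 (within the scatter) that stays within the scatter.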

Compound 4, a percentage reported as inhibition, at one concentration (the size of the read-out at that concentration, not a potency): 0.03%
Beside the measured number, compound 4's estimate is 9 percentage points below it; low and high end bracket the measured number.
By their numbers in this assay, from the lowest: compound 2; then compounds 3, 1 and 4 (each within the scatter of the next, the first and the last beyond it).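

At this place, on a saturated chain carbon bound to an aromatic nitrogen, this assay now shows a change of group that goes beyond the scatter: phenyl in place of 3,4,5-trimethoxyphenyl gives a number 10.9 percentage points higher from compound 3 to compound 4 (beyond the scatter), a modest step. Hydrogen in place of fluoro on an aromatic carbon gives a number 7.6 percentage points higher from compound 1 to compound 4 (within the scatter), so these two compounds cannot be told apart. No measured evidence explains either step. As far as these compounds go, whether an amine or a carboxylic acid on that aromatic ring would move the number in this assay remains open.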